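Adding a Methylphenyl Group to a Weak Amine

The source may hold more compounds than are shown below. What is called first, only, known or untested is meant among the compounds shown, and "the series" means these compounds.

Of the compounds shown here, three built on one shared core have been measured in an assay on CHO cells for displacement of a labelled ligand from adenosine receptor A3 (Homo sapiens); on this read-out lower numbers stand for stronger inhibition and higher numbers for weaker inhibition. Compound 1 `COc1ccc(CNc2ncc(C(=O)O)c3nc(-c4ccco4)nn23)cc1OC` gives 159 nM. Compound 2 `CCOC(=O)c1cnc(NC2CCCCC2)n2nc(-c3ccco3)nc12` gives 131 nM. Compound 3 `CNc1ncc(C(=O)O)c2nc(-c3ccco3)nn12` gives 15900 nM, the highest of the three numbers; its gaps to compound 1 and to compound 2 both lie beyond the scatter, so compound 3 is clearly the weakest binder of the three.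

Compound 4 `Cc1ccc(CNc2ncc(C(=O)O)c3nc(-c4ccco4)nn23)cc1` has not yet been measured. It differs from compound 3 by 4-methylphenyl in place of hydrogen on a saturated chain carbon bound to a nitrogen on an aromatic ring. Compound 1 also carries a substituted benzyl group on that same nitrogen and gives 159 nM, far below compound 3, so an aryl ring on that chain carbon appears to go with much stronger binding, though only compound 1 and compound 3 speak to this. A large downward step is therefore expected, a 110-fold lower number from compound 3 to compound 4 (2.03 log units; beyond the scatter). Compound 4 is estimated at 150 nM, with a likely range from 50 nM to 500 nM.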

Compound 4, inhibition constant: 751 nM
Estimate against measurement, compound 4: 5.0-fold (0.70 log units) below; the measured number lies above the stated range.
By their numbers in this assay, from the lowest: compounds 2 and 1 (each within the scatter of the next); then compound 4; then compound 3.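

In this assay, among these compounds, the swap of hydrogen for 4-methylphenyl on this saturated chain carbon gives a 21-fold lower number from compound 3 to compound 4 (1.33 log units; beyond the scatter) and is the first change here made at one place only. It shows that a large gain in binding at this position does not need the two methoxy groups of compound 1, since a ring carrying a single methyl is enough. Nothing available explains why the ring has this effect.

The compounds shown leave open whether the methyl contributes at all, which a plain phenyl ring would test, and whether a chlorine or an amine in its place would do better or worse. They also leave open how the number responds to a longer chain, such as 2-phenylethyl, holding the ring further from the nitrogen.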